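This account rests on a few compounds, and the source may have more. Where it says the series, first, only, none or still open, it means among the compounds named here.

Measured so far:
- compound 1 `COc1ccc(-c2ccc3c(NCCCNCc4cccc(OC)c4O)ccnc3c2)cc1` gives 9.47
- compound 2 `CC(C)(C)c1ccc(Oc2ccc3c(NCCCNCc4ccco4)ccnc3c2)cc1` gives 9.28
- compound 3 `Cc1cc(C)cc(Cc2ccc3c(NCCCNCc4ccco4)ccnc3c2)c1` gives 9.47

All three numbers come from a physicochemical assay for acid dissociation. Compound 1 stands level with compound 3 , and compound 2 lies within the usual scatter of both, so the three values do not separate.

Next in the series is compound 4 `COc1cccc(CNCCCNc2ccnc3cc(CCC(C)C)ccc23)c1O`, which keeps everything else of compound 1 and changes one group. The change is isopentyl in place of 4-methoxyphenyl on an aromatic carbon, at a place meta to a fused ring and para to a fused ring.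

For the measured compounds named here, no measured pair differs in one place only, so no direct step can be carried over. The guide is the spread of the values. Compound 2 at 9.28 and compound 3 at 9.47 carry other groups at that place and stay within the scatter of compound 1 , so no change beyond the scatter is expected here. The estimated step of a number 0.07 log units lower from compound 1 to compound 4 (within the scatter) is expected to stay within the scatter.

For compound 4 the estimated value is 9.4, with an expected range from 9.1 to 9.7.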

Compound 4, acid dissociation constant: 9.47
Compound 4: the middle estimate sits 0.07 log units below what was measured; low and high end bracket the measured number.
By their numbers in this assay, from the lowest: compounds 2, 1, 3 and 4 (each within the scatter of the next).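

Isopentyl in place of 4-methoxyphenyl on an aromatic carbon gives no change at the digits printed from compound 1 to compound 4 (within the scatter) in this assay, and this is the first step in the series that differs in one place only. For the compounds shown here, the position can now be read directly, no longer only through compounds that also differ elsewhere. Even with the loss of the six-membered aromatic ring and the hydrogen-bond acceptor of 4-methoxyphenyl, and a move from 8 heavy atoms to 5, the read-out stays within the scatter, although no measured information on hand explains this outcome.

This single step leaves open whether a group of another kind at this place, such as a carboxylic acid or an amine, would also stay within the scatter of compound 1 or would move the number beyond it. Also open, going by these compounds, is whether a one-place change elsewhere on compound 1, such as a longer chain in place of the isopentyl-free part of the molecule that carries the two side-chain nitrogens, would leave the number equally unmoved.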